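The source may hold more compounds than are shown below. What is called first, only, known or untested is meant among the compounds shown, and "the series" means these compounds.

Measured so far:
compound 1, `O=[N+]([O-])c1ccc(S(=O)(=O)NCCCCCCNCc2ccc(Br)cc2)cc1` — 9800 nM
compound 2, `CC(C)c1ccc(S(=O)(=O)NCCCCCCNCc2ccc(Br)cc2)cc1` — 5730 nM

Both compounds were run in a functional assay on MIA PaCa-2 cells (Homo sapiens) for inhibition, read by MTT assay, with a stated time of 72 h; on this read-out higher numbers stand for weaker inhibition of growth and lower numbers for stronger inhibition of growth. Among the compounds with values here, compound 1 gives 9800 nM and compound 2 gives 5730 nM; the single measured step, a 1.7-fold lower number from compound 1 to compound 2 (0.23 log units; within the scatter), is an exchange of isopropyl for nitro on an aromatic carbon and does not separate the two beyond the scatter. Compound 2 therefore cannot be called the more active of the pair; it stands with compound 1 on a single level.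

Compound 3, `O=S(=O)(NCCCCCCNCc1ccc(Br)cc1)c1ccc(Cl)cc1`, is not yet measured. It differs from compound 2 by chloro in place of isopropyl on an aromatic carbon. Within the data shown here, no measured step touches this change: the only step known concerns a different group at the same place, and it was within the scatter. With two substituents of unlike character already giving the same level, the expectation is that compound 3 lands on that level too. The estimated step of a 1.1-fold higher number from compound 2 to compound 3 (0.05 log units; within the scatter) is expected to stay within the scatter. For compound 3 the expected value in this assay is 6500 nM, with a range from 2500 nM to 16000 nM.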

Compound 3, concentration for 50% growth inhibition: 5900 nM
Beside the measured number, compound 3's estimate is 1.1-fold (0.04 log units) above it; the range from low to high includes it.
By their numbers in this assay, from the lowest: compounds 2, 3 and 1 (each within the scatter of the next).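

In this assay the exchange of 4-isopropylphenyl for 4-chlorophenyl gives a 1.0-fold higher number from compound 2 to compound 3 (0.01 log units; within the scatter), and chloro in place of nitro gives a 1.7-fold lower number from compound 1 to compound 3 (0.22 log units; within the scatter). With this third group, the aromatic carbon para to a large group carries nitro, isopropyl or chloro with all three compounds on a single level, and even the change from isopropyl with 3 heavy atoms to chloro with 1 heavy atom does not separate compound 2 from compound 3, so among these three compounds the read-out shows no dependence on the substituent at this place. No measured information bears on why these substituents give one level, and the result is left without an explanation.

The compounds shown leave open whether this level would hold with an amine, a carboxylic acid or a longer alkyl chain at the same aromatic carbon. They also leave open whether a change elsewhere in the shared core, such as replacing the bromo group with a methoxy group or altering the chain that links the two aromatic parts, would move the number beyond the scatter.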